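A few compounds are considered here, and "the series" means these few. Any claim that something is new, unique, unknown or untested is made for them only; others in the source may bear on it.

Of the compounds shown here, three from this set have been tested in a functional assay on OVCAR cells (Homo sapiens) for inhibition, read by MTT assay, with a stated time of 48 h; on this read-out higher numbers stand for weaker inhibition of growth and lower numbers for stronger inhibition of growth. Compound 1 `COc1ccc(-c2cc(-c3ccc([N+](=O)[O-])cc3)[nH]n2)cc1OC` gives 28900 nM. Compound 2 `COc1ccc(-c2cc(-c3ccc(Cl)cc3)n[nH]2)cc1` gives 12800 nM. Compound 3 `FC(F)(F)c1ccc(-c2cc(-c3ccccc3-c3ccccc3)n[nH]2)cc1` gives 2750 nM, the lowest of the three numbers: its gap to compound 2 and its wider gap to compound 1 both lie beyond the usual scatter, so compound 3 is the strongest inhibitor of growth among these three. Going by the values given here, no two of the measured compounds differ in only one place, so no single structural step has yet been followed by measurement within this set.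

Compound 4 `Nc1ccc(-c2cc(-c3ccccc3-c3ccccc3)n[nH]2)cc1` differs from compound 3 in one place: amino in place of trifluoromethyl on an aromatic carbon. Among the compounds with values here, nothing among the measured compounds shows how this particular change moves the read-out, since compound 1 and compound 2 carry other groups on other parts of the shared core. Within the data shown here, with no comparable step to lean on, the expectation for compound 4 is at most a small loss of growth inhibition, a 1.8-fold higher number from compound 3 to compound 4 (0.26 log units; within the scatter), a step that may well stay within the scatter. Compound 4 is therefore estimated at 5000 nM, with a range from 1500 nM to 20000 nM.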

Compound 4, concentration for 50% growth inhibition: 17900 nM
For compound 4 the middle estimate is 3.6-fold (0.55 log units) below the measured one; low and high end bracket the measured number.
By their numbers in this assay, from the lowest: compound 3; then compounds 2, 4 and 1 (each within the scatter of the next, the first and the last beyond it).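

Going by these compounds alone, this is the first single change in the set that can be followed by measurement. In this assay amino in place of trifluoromethyl on an aromatic carbon brings a 6.5-fold higher number from compound 3 to compound 4 (0.81 log units; beyond the scatter) and so weakens inhibition of growth, which shows that the read-out is sensitive to the group at this position, para to a large group. The swap replaces four heavy atoms and no hydrogen-bond donor with one nitrogen that counts as one donor and one acceptor, but no measurement of any property is available to link either difference to the step.

A single pair cannot show whether the weaker inhibition comes from gaining amino or from losing trifluoromethyl, and it cannot show whether the same swap would have a similar effect elsewhere on the shared core. A methyl group, a hydroxyl group or a carboxylic acid at the same position would help separate these possibilities by showing how the read-out changes across a wider range of groups.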